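The compounds below may be only part of what the source reports. "The series", "measured", "known", "first", "only" and "open" are said of these compounds alone.

Measured so far:
compound 1, `Oc1cccc(-c2cc(-c3ccsc3)cc(-c3cccc(O)c3)n2)c1`: 1510 nM
compound 2, `Oc1ccc(-c2cc(-c3ccsc3)cc(-c3cccc(O)c3)n2)cc1`: 760 nM
compound 3, `Oc1cccc(-c2cc(-c3ccco3)cc(-c3ccccc3O)n2)c1`: 820 nM

These three were tested in a functional assay on T47D cells (Homo sapiens) for cytotoxicity, read by CCK-8 assay; a higher number here means a weaker inhibitor, a lower number a stronger inhibitor. Compound 4, `Oc1ccc(-c2cc(-c3ccco3)cc(-c3ccccc3O)n2)cc1`, has not yet been tested there. It differs from compound 3 by 4-hydroxyphenyl in place of 3-hydroxyphenyl on an aromatic carbon. The same kind of change has already been made once, from compound 1 to compound 2, where it gave a 2.0-fold lower number from compound 1 to compound 2 (0.30 log units; within the scatter); there it read (4-hydroxyphenyl in place of 3-hydroxyphenyl on an aromatic carbon). The surroundings are not identical: in the earlier pair the place is meta to a 3-hydroxyphenyl group and meta to a thiophen-3-yl group, in the new pair meta to a 2-hydroxyphenyl group and meta to a furan-2-yl group. The difference between the two cores is not broken down here. A step of about the same size is expected for compound 4, namely a 1.6-fold lower number from compound 3 to compound 4 (0.21 log units; within the scatter), because the earlier step was a 2.0-fold lower number from compound 1 to compound 2 (0.30 log units; within the scatter). Compound 4 is therefore estimated at 500 nM, likely between 250 nM and 1200 nM.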

Compound 4, half-maximal inhibitory concentration: > 50000 nM
Compound 4: a limit, no number; the forecaster's own chance of this, stated with the estimate: 2%; middle value at least 100-fold (2.00 log units) from the limit.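

In this assay, putting 4-hydroxyphenyl in place of 3-hydroxyphenyl gave an at least 60-fold higher number from compound 3 to compound 4 (1.78 log units; beyond the scatter). Compound 4 reads > 50000 nM, which is a limit of the assay and not a number. The change therefore does not carry over from one core to the other with the same size or direction, though two pairs cannot show which difference between the cores matters, and the two steps stand apart: the same change on two cores in this assay, a 2.0-fold lower number (0.30 log units; within the scatter) from compound 1 to compound 2 and an at least 60-fold higher number (1.78 log units; beyond the scatter) from compound 3 to compound 4, at least 120-fold (2.08 log units) apart, beyond the scatter of two such steps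

No pair shown changes the furan-2-yl group or the 2-hydroxyphenyl group on its own, so it remains open whether either one decides the outcome. Also open, on these data alone, is how an amine or a carboxylic acid would behave in place of the hydroxyl on the 4-hydroxyphenyl group.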